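Replacing a Methyl with a Cyclohexylmethyl on the Hydrazide Nitrogen

This account rests on a few compounds, and the source may have more. Where it says the series, first, only, none or still open, it means among the compounds named here.

Three compounds of one series have been run in an assay on cells for agonist activity at ecdysone receptor (Bombyx mori), read by a luciferase reporter, with a stated time of 24 h; on this read-out higher numbers stand for an effect only at larger amounts of compound and lower numbers for an effect already at smaller amounts. Compound 1 `COc1ccccc1C(=O)N(NC(=O)c1ccccc1)C(C)(C)C` gives 525 nM in this assay. Compound 2 `CC(C)(C)N(NC(=O)c1ccccc1I)C(=O)c1ccccc1Cl` gives 1290 nM in this assay. Compound 3 `CN(NC(=O)c1ccccc1)C(=O)c1ccccc1` stands apart from these two. Its entry in this assay is a limit and not a number, > 100000 nM, so for compound 3 only a bound is known. On the numbers shown, compound 3 thus sits at the limit of the limit of > 100000 nM in this assay, at which 1 of the 3 values shown sits, whereas compounds 1 and 2 both fall within the measured range; both of them differ from compound 3 in more than one place, so no single measured step connects them to it.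

Compound 4 `O=C(NN(CC1CCCCC1)C(=O)c1ccccc1)c1ccccc1` is not yet measured. It differs from compound 3 by cyclohexyl in place of hydrogen on a saturated chain carbon bound to an amide-type nitrogen. Among the compounds with values here, no measured step of this kind exists among the three compounds, so the size of the change has to be estimated. Compound 1 gives 525 nM in this assay and so lies within the measured range. Given that compound 3 sits at the limit (the limit of > 100000 nM in this assay, at which 1 of the 3 values shown sits), the step from compound 3 to compound 4 is expected to be an at least 33-fold lower number from compound 3 to compound 4 (1.52 log units; beyond the scatter), toward an effect at smaller amounts and well beyond the usual scatter. For compound 4 the expected value in this assay is 3000 nM. The range for compound 4 is estimated to run from 400 nM to 30000 nM.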

Compound 4, half-maximal effective concentration: 1700 nM
Estimate against measurement, compound 4: 1.8-fold (0.25 log units) above, and the stated range covers the measured number.
By their numbers in this assay, from the lowest: compound 1; then compounds 2 and 4 (each within the scatter of the next). At a limit, above all of these: compound 3.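

Until now no single measured change had connected two compounds of this series, and in this assay cyclohexyl in place of hydrogen on a saturated chain carbon bound to an amide-type nitrogen gives an at least 58-fold lower number from compound 3 to compound 4 (1.76 log units; beyond the scatter). The entry for compound 3 is a limit and not a number, so this step gives only a bound on the size of the change: the limit of > 100000 nM in this assay, at which 1 of the 4 values shown sits.

It also shows that a change at this one place is enough to bring the core of compound 3 into the measured range, with compound 4 at 1700 nM, and that a six-membered non-aromatic ring of carbon only is accepted there.

The compounds shown leave open how a shorter or longer chain, such as an ethyl or a hexyl group, or a phenyl ring or an amine at the same place, would read in this assay. They also leave open whether the same change would give a step of like size on the cores of compound 1 and compound 2.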